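The source may report more compounds than this note shows. Statements on the series, on what has been measured and on what is new or still open speak of the compounds shown alone.

Compound 1 (`COc1cc(NC(=O)/C=C/c2cccc(OCc3ccccc3)c2)cc(OC)c1OC`): 3600 nM
Compound 2 (`C=C(Br)C(=O)Nc1cccc(/C=C/C(=O)Nc2ccccc2)c1`): 16600 nM
Compound 3 (`C=C(Br)C(=O)Nc1cccc(/C=C/C(=O)Nc2cccc(F)c2)c1`): 4600 nM

All three compounds were tested in a functional assay on HT-29 cells (Homo sapiens) for inhibition, read by MTT assay, with a stated time of 72 h; on this read-out lower numbers stand for stronger inhibition and higher numbers for weaker inhibition. There compound 3 gives 4600 nM, well under compound 2 and within the usual scatter of compound 1.

The next molecule, compound 4 (`C=C(Br)C(=O)Nc1cccc(/C=C/C(=O)Nc2ccc(C)cc2)c1`), has 4-methylphenyl in place of 3-fluorophenyl on an amide-type nitrogen. For the measured compounds named here, only one measured step bears on this change: a 3.6-fold lower number from compound 2 to compound 3 (0.56 log units; beyond the scatter), where fluoro replaced hydrogen on an aromatic carbon. Compound 4 carries no fluoro, so it may give back part of that step. Going by the values given here, no measured step shows what a methyl group does, so this reasoning remains uncertain. A modest move towards a higher number is therefore expected in this assay. The expected step is a 2.2-fold higher number from compound 3 to compound 4 (0.34 log units; beyond the scatter). The estimate for compound 4 is 10000 nM, with an expected range from 3500 nM to 25000 nM.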

Compound 4, half-maximal inhibitory concentration: 1200 nM
Compound 4: the middle estimate sits 8.3-fold (0.92 log units) above what was measured; the measured number lies below the stated range.
By their numbers in this assay, from the lowest: compound 4; then compounds 1 and 3 (each within the scatter of the next); then compound 2.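

In this assay a methyl group taking the place of a ring hydrogen gives a 14-fold lower number from compound 2 to compound 4 (1.14 log units; beyond the scatter) and so shows that a fluoro group is not needed for a lower number in this series. Placing 4-methylphenyl instead of 3-fluorophenyl on the amide-type nitrogen gives a 3.8-fold lower number from compound 3 to compound 4 (0.58 log units; beyond the scatter) and so shows that these two groups are not interchangeable at this position. No measurement shown here explains this difference.

The compounds shown do not separate the effect of the methyl group itself from the effect of its place on the ring. Going by these compounds, how a longer carbon chain or an amine on this ring would compare with 4-methylphenyl also remains open.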